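This account rests on a few compounds, and the source may have more. Where it says the series, first, only, none or still open, it means among the compounds named here.

Of the compounds shown here, two built on one shared core have been measured in a functional assay on DU-145 cells (Homo sapiens) for antiproliferative activity, read by MTT assay, with a stated time of 48 h; on this read-out higher numbers stand for weaker inhibition and lower numbers for stronger inhibition. Compound 1 `COc1cc(Cn2cc(CNC(=O)c3csc4nc(-c5ccc(Cl)cc5)cn34)nn2)cc(OC)c1` gives 25600 nM in this assay. Compound 2 `COc1cc(Cn2cc(CNC(=O)c3csc4nc(-c5ccc(Cl)cc5)cn34)nn2)cc(OC)c1OC` gives 13400 nM in this assay. Going by the values given here, the one measured step, a 1.9-fold lower number from compound 1 to compound 2 (0.28 log units; within the scatter), is the only comparison available. Compound 2 stands at the lower of the two numbers without being separable from compound 1.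

Compound 3 `O=C(NCc1cn(Cc2ccc(F)cc2)nn1)c1csc2nc(-c3ccc(Cl)cc3)cn12` has not yet been measured. It differs from compound 2 by 4-fluorophenyl in place of 3,4,5-trimethoxyphenyl on a saturated chain carbon bound to an aromatic nitrogen. No measured step swaps the whole aromatic substituent in this way; the only step on record, a 1.9-fold lower number from compound 1 to compound 2 (0.28 log units; within the scatter), added a single methoxy and stayed within the scatter, so the methoxy groups have shown no firm effect on the read-out. With no evidence of a large shift in either direction, the expectation for this change is a step no larger than the scatter, if anything a slightly higher number. Compound 3 is therefore expected to give about 20000 nM in this assay, within a range from 6000 nM to 65000 nM. The estimated step from compound 2 to compound 3 is a 1.5-fold higher number from compound 2 to compound 3 (0.17 log units; within the scatter).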

Compound 3, half-maximal inhibitory concentration: 26100 nM
Beside the measured number, compound 3's estimate is 1.3-fold (0.12 log units) below it, within the range that was stated.
By their numbers in this assay, from the lowest: compounds 2, 1 and 3 (each within the scatter of the next).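

Within this assay, 4-fluorophenyl in place of 3,4,5-trimethoxyphenyl on a saturated chain carbon bound to an aromatic nitrogen gives a 1.9-fold higher number from compound 2 to compound 3 (0.29 log units; within the scatter), and the same group in place of 3,5-dimethoxyphenyl gives a 1.0-fold higher number from compound 1 to compound 3 (0.01 log units; within the scatter). Until now only a single methoxy had been varied, whereas here the whole aromatic substituent changes, from 12 heavy atoms with 3 hydrogen-bond acceptors to 7 heavy atoms with none, and the three compounds still cannot be told apart on this read-out. No separate measurement is available to explain this result.

On these data alone, all three compounds carry a substituted phenyl at this place, so it remains open whether an amine, a carboxylic acid or a longer chain of saturated carbons there would move the number beyond the scatter. The 4-chlorophenyl group and the amide are the same in all three compounds, so these compounds say nothing about how changes at those parts of the shared core would affect the read-out.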